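Methoxymethyl in Place of Phenyl on a Fused Core

The source may report more compounds than this note shows. Statements on the series, on what has been measured and on what is new or still open speak of the compounds shown alone.

Three compounds have so far been tested in a functional assay for inhibition, with Homo sapiens as the target; a lower number here means a stronger inhibitor, a higher number a weaker inhibitor:

Compound 1, `COCc1ncc2cnnc(SC)n12`, gives > 48000 nM, which is a limit of the assay.
Compound 2, `COCc1ncc2cnnc(S)n12`, gives > 48000 nM, again a limit.
Compound 3, `C=CCSc1nncc2cnc(-c3ccccc3)n12`, gives > 48000 nM, also a limit.

Among the measured compounds shown here, only one pair differs in a single place, compound 1 and compound 2, and the step that the two limits leave unreadable from compound 1 to compound 2 cannot be read: both of its ends are limits. Compound 3 therefore stands at the same limit as the other two, and the whole picture is summed up by the limit of > 48000 nM in this assay, at which 3 of the 3 values shown sit.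

Compound 4, `C=CCSc1nncc2cnc(COC)n12`, is the next compound. It differs from compound 3 by methoxymethyl in place of phenyl on an aromatic carbon. For the measured compounds named here, no measured step covers this change, and none of the measured values rises above the limit. The expectation for the step from compound 3 to compound 4 is therefore no readable change, a step that the limit leaves unreadable from compound 3 to compound 4, with a limit again the likeliest outcome in this assay. On this basis compound 4 is estimated at 70000 nM, with a range from 20000 nM to 250000 nM.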

Compound 4, half-maximal inhibitory concentration: 79000 nM
Beside the measured number, compound 4's estimate is 1.1-fold (0.05 log units) below it; low and high end bracket the measured number.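

The steps from compound 1, compound 2 and compound 3 to compound 4 cannot be read, because each of them has a limit at one end: the limit of > 48000 nM in this assay, at which 3 of the 4 values shown sit.

The compounds shown leave open whether methoxymethyl in place of phenyl, or any other change among them, alters inhibition at all.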